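Methyl for phenyl on the ring amide nitrogen

The source may hold more compounds than are shown below. What is called first, only, known or untested is meant among the compounds shown, and "the series" means these compounds.

Measured compounds:
compound 1, `CN1C(=O)C2ON=C(c3cn(-c4ccccc4)nc3-c3ccc(Br)cc3)C2C1=O`, 40.4%
compound 2, `CCOc1ccc(-c2nn(-c3ccccc3)cc2C2=NOC3C(=O)N(c4ccccc4)C(=O)C23)cc1`, 49.5%

The study rests on two measured compounds. In a functional assay on the whole organism (Abdomen, strain Swiss albino) with Mus musculus as the target, with stated times of 10 min and 5 min, at a dose of 30 mg/kg by the oral route (on this read-out lower numbers stand for a weaker effect and higher numbers for a stronger effect at the one dose given), compound 1 gives 40.4%, and compound 2 gives 49.5%. Compound 2 holds the higher of the two numbers, yet its gap to compound 1 lies within the scatter, so the two cannot be ordered against each other. Among the measured compounds shown here, compound 1 and compound 2 differ in two places at once, so no single step between them can be drawn.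

Compound 3, `CCOc1ccc(-c2nn(-c3ccccc3)cc2C2=NOC3C(=O)N(C)C(=O)C23)cc1`, has not yet been measured. It differs from compound 2 in one place: methyl in place of phenyl on an amide-type nitrogen in a ring. Compound 1 already carries a methyl on that same ring nitrogen, and its reading in this assay is within the scatter of compound 2, so the change gives no reason to expect a shift beyond the scatter in either direction. Compound 3 is therefore estimated to lie close to both measured compounds, at 44% with a range from 28% to 60%, which means an expected step of a number 5.5 percentage points lower from compound 2 to compound 3 (within the scatter).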

Compound 3, a percentage reported as activity, at one dose (the size of the read-out at that dose, not a potency): 47.5%
Compound 3: the middle estimate sits 3.5 percentage points below what was measured, and the stated range covers the measured number.
By their numbers in this assay, from the lowest: compounds 1, 3 and 2 (each within the scatter of the next).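

In this assay, methyl in place of phenyl on the amide-type nitrogen in the ring gives a number 2 percentage points lower from compound 2 to compound 3 (within the scatter), so with ethoxy held constant, this position shows no difference beyond the scatter when the six-carbon aromatic ring gives way to a single carbon. Among the compounds shown here, the new compound also gives the first one-place comparison with compound 1: in this assay, ethoxy in place of bromo on an aromatic carbon gives a number 7.1 percentage points higher from compound 1 to compound 3 (within the scatter), so compounds that previously differed in two places are now linked by two single changes, each within the scatter. The data offer no measured explanation for either step.

The compounds shown leave open whether a different group on that ring nitrogen, such as a longer chain or a chain ending in an amine or a carboxylic acid, would give a reading beyond the scatter. They also leave open whether the exchange of phenyl for methyl would read the same with bromo in place of ethoxy, and how the size of the effect at this one dose would compare with that at other doses.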